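Replacing 3,4-difluorophenyl by pyridin-4-yl: working notes

A few compounds are considered here, and "the series" means these few. Any claim that something is new, unique, unknown or untested is made for them only; others in the source may bear on it.

Values in an in vitro ADME assay on microsomes from liver (Rattus norvegicus) for metabolic stability (a lower number here means slower removal, a higher number faster removal of the compound), so far:
- compound 1 `CC(C)NC(=O)[C@H]1CC[C@@H](n2/c(=N/C(=O)c3ccc(C#N)c(F)c3)[nH]c3ccc(CN4CCC(C(C)(C)O)CC4)cc32)CC1` gives 29 mL.min-1.g-1
- compound 2 `CC(C)NC(=O)[C@H]1CC[C@@H](n2/c(=N/C(=O)c3cccc(C#N)c3)[nH]c3ccc(CN4CCC(C(C)(C)O)CC4)cc32)CC1` gives 17 mL.min-1.g-1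
- compound 3 `CC(C)NC(=O)[C@H]1CC[C@@H](n2/c(=N/C(=O)c3ccc(F)c(F)c3)[nH]c3ccc(CN4CCC(C(C)(C)O)CC4)cc32)CC1` gives 19 mL.min-1.g-1

Compound 3 lies within the scatter of both others, with steps (a 1.5-fold lower number from compound 1 to compound 3 (0.18 log units; within the scatter)) and (a 1.1-fold higher number from compound 2 to compound 3 (0.05 log units; within the scatter)). Unmeasured compound 4 `CC(C)NC(=O)[C@H]1CC[C@@H](n2/c(=N/C(=O)c3ccncc3)[nH]c3ccc(CN4CCC(C(C)(C)O)CC4)cc32)CC1` carries pyridin-4-yl in place of 3,4-difluorophenyl on a carbonyl carbon. Among the measured compounds shown here, no measured compound has a hetero atom in that ring, so the evidence is indirect: the remaining aromatic swap (a 1.7-fold lower number from compound 1 to compound 2 (0.23 log units; within the scatter)) also stayed within the scatter. In this assay no change beyond the scatter is therefore expected, in either direction (a 1.1-fold lower number from compound 3 to compound 4 (0.05 log units; within the scatter)). For compound 4 the expected value is 17 mL.min-1.g-1 within an estimated range (8 mL.min-1.g-1 to 34 mL.min-1.g-1).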

Compound 4, intrinsic clearance in microsomes: < 14 mL.min-1.g-1
Compound 4: only a limit was reported; the forecaster's own chance of this, stated with the estimate: 5%; middle value at least 1.2-fold (0.08 log units) from the limit.
By their numbers in this assay, from the lowest: compounds 2, 3 and 1 (each within the scatter of the next). At a limit, below all of these: compound 4.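

In this assay compound 4 gives < 14 mL.min-1.g-1, which is a limit and not a number. With pyridin-4-yl, the only ring with a hetero atom on this carbonyl carbon among the compounds shown, one step at this position now reaches beyond the scatter, an at least 2.0-fold lower number from compound 1 to compound 4 (0.31 log units; beyond the scatter), while the other two have floors within it, an at least 1.3-fold lower number from compound 3 to compound 4 (0.13 log units; that floor lies within the scatter) and an at least 1.2-fold lower number from compound 2 to compound 4 (0.08 log units; that floor lies within the scatter). Compound 4 alone stands at the limit: the limit of < 14 mL.min-1.g-1 in this assay, at which 1 of the 4 values shown sits.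

Open, as far as these compounds go, is whether the ring nitrogen itself matters, as a single pyridine cannot settle that. Pyridin-3-yl or pyrimidin-5-yl on the same carbonyl carbon would test this.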